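Replacing a Chloropropyl Amide by an Acrylamide on Two Cores

This account rests on a few compounds, and the source may have more. Where it says the series, first, only, none or still open, it means among the compounds named here.

Measured compounds:
Compound 1, `CC(C)(C)c1ccc(NC(=O)CCCCl)cc1`, reaches only a limit in a functional assay on HT-29 cells (Homo sapiens) for antiproliferative activity, with a stated time of 48 h; a higher number here means a weaker inhibitor, a lower number a stronger inhibitor: compound 1 gives > 100000 nM.
Compound 2, `CC(C)(C)c1ccc(CNC(=O)CCCCl)cc1`, gives 72000 nM in this assay.
Compound 3, `C=CC(=O)Nc1ccc(C(C)(C)C)cc1`, gives 24000 nM in this assay.

Compound 1 and compound 3 share one core and differ in a single change, (vinyl in place of 3-chloropropyl on a carbonyl carbon). In this assay that change gives an at least 4.1-fold lower number from compound 1 to compound 3 (0.61 log units; beyond the scatter). The size of this step cannot be pinned down more closely, since it rests on (the limit of > 100000 nM in this assay, at which 1 of the 3 values shown sits).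

The second pair is built on another core. Compound 2 is the measured member; compound 4, `C=CC(=O)NCc1ccc(C(C)(C)C)cc1`, is not yet measured. How the core of compound 2 differs from the core of compound 1 is not broken down here. Compound 4 differs from compound 2 by vinyl in place of 3-chloropropyl on a carbonyl carbon. The surroundings of the change are described in the same words for both pairs, so this is the same change, made a second time.

Among the measured values in this assay, compound 2 stands highest, with compound 3 nearest to it. Within the data shown here, on the strength of the one earlier step, the step from compound 2 to compound 4 is expected to be a 4.0-fold lower number from compound 2 to compound 4 (0.60 log units; beyond the scatter), beside an at least 4.1-fold lower number from compound 1 to compound 3 (0.61 log units; beyond the scatter); this rests on that step alone and on the starting point of compound 2, 72000 nM. Compound 4 is therefore estimated to give about 18000 nM in this assay, expected to fall between 6000 nM and 55000 nM.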

Compound 4, half-maximal inhibitory concentration: > 100000 nM
Compound 4: only a limit was reported (the forecaster's own chance of this, stated with the estimate: 5%); middle value at least 5.5-fold (0.74 log units) from the limit.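

In this assay, vinyl in place of 3-chloropropyl on a carbonyl carbon did not carry over from one core to the other, and the two steps differ by more than repeated measurements would explain: the same change on two cores in this assay, an at least 4.1-fold lower number (0.61 log units; beyond the scatter) from compound 1 to compound 3 and an at least 1.3-fold higher number (0.14 log units; that floor lies within the scatter) from compound 2 to compound 4, at least 5.7-fold (0.76 log units) apart, beyond the scatter of two such steps

On the core of compound 2 the change gives an at least 1.3-fold higher number from compound 2 to compound 4 (0.14 log units; that floor lies within the scatter), so the lower number seen on the core of compound 1 does not recur, but the true size of this step stays unknown, as does that of the earlier one, since each rests on a limit and not on a number: the limit of > 100000 nM in this assay, at which 2 of the 4 values shown sit.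

What this shows is that, across these two pairs, the effect of the change depends on the core it is made on; it does not show what sets the two cores apart in this respect, and two pairs give no rule for any further core.

The compounds shown leave open whether the vinyl group itself matters, as an ethyl group on the same carbonyl carbon would be needed on both cores to read that. They also leave open how a longer chain carrying the chlorine, or an amine in its place, would stand on either core.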